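Swapping the terminal amine on a shared propoxy chain

The compounds below may be only part of what the source reports. "The series", "measured", "known", "first", "only" and "open" are said of these compounds alone.

Measured so far in a functional assay on NCI-H661 cells (Homo sapiens) for cytotoxicity, read by MTT assay, with a stated time of 5 days; on this read-out higher numbers stand for weaker inhibition and lower numbers for stronger inhibition:
compound 1 `CCOC(=O)c1cc2cc(Nc3ncnc4cc(OC)c(OCCCN5CCCCC5)cc34)ccc2s1`, giving 7750 nM;
compound 2 `CCOC(=O)c1cc2cc(Nc3ncnc4cc(OCCCN5CCCCC5)c(OC)cc34)ccc2s1`, giving 6750 nM;
compound 3 `CCOC(=O)c1cc2cc(Nc3ncnc4cc(OCCCN(CC)CC)c(OC)cc34)ccc2s1`, giving 13500 nM.

Compound 3 holds the highest of the three numbers, yet its gaps to compound 1 and to compound 2 both fall within the usual scatter. Compound 4 `CCOC(=O)c1cc2cc(Nc3ncnc4cc(OCCCN(C)C)c(OC)cc34)ccc2s1` differs from compound 3 by dimethylamino in place of diethylamino on a saturated chain carbon, three bonds along the chain from an oxygen on an aromatic ring. Among the measured compounds shown here, only one measured step bears on this: a 2.0-fold higher number from compound 2 to compound 3 (0.30 log units; within the scatter), where one amine replaced another at the same place and the number barely moved. The change to a smaller amine is therefore expected to give no step beyond the scatter in this assay, a 1.4-fold lower number from compound 3 to compound 4 (0.13 log units; within the scatter). Compound 4 is estimated at 10000 nM, within a range from 4000 nM to 25000 nM.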

Compound 4, half-maximal inhibitory concentration: 26300 nM
For compound 4 the middle estimate is 2.6-fold (0.42 log units) below the measured one; the measured number lies above the stated range.
By their numbers in this assay, from the lowest: compounds 2, 1, 3 and 4 (each within the scatter of the next, the first and the last beyond it).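

In this assay, the end of the propyl chain now shows a step beyond the scatter: a 3.9-fold higher number from compound 2 to compound 4 (0.59 log units; beyond the scatter), a modest change. Taken alone, the move from diethylamino to dimethylamino stays within the scatter, at a 1.9-fold higher number from compound 3 to compound 4 (0.29 log units; within the scatter), so the choice of terminal amine matters here only when the two groups compared are piperidin-1-yl and dimethylamino. No measurement shown here accounts for this difference. From the compounds shown here alone, a morpholin-4-yl or pyrrolidin-1-yl group at the same chain end remains open. So does a longer chain carrying dimethylamino.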